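The source may report more compounds than this note shows. Statements on the series, on what has been measured and on what is new or still open speak of the compounds shown alone.

Within the data shown here, compound 3 `COc1ccc(F)cc1CNCCCNc1ccnc2cc(Cc3cc(C)cc(C)c3)ccc12` gives 940 nM in an ADME assay on HepG2 cells (Homo sapiens) for cytotoxicity, read by luminescence, CellTiter-Glo and ATP content, with a stated time of 72 h (on this read-out higher numbers stand for an effect only at larger amounts of compound and lower numbers for an effect already at smaller amounts), the lowest of the three numbers measured so far. Compound 1 `COc1cccc(Oc2ccc3c(NCCCNCc4cc(F)ccc4OC)ccnc3c2)c1` gives 7100 nM in this assay, and compound 2 `COc1ccc(-c2ccc3c(NCCCNCc4cc(F)ccc4OC)ccnc3c2)cc1` gives 5960 nM. Compound 4 `COc1ccc(F)cc1CNCCCNc1ccnc2cc(Oc3ccccc3OC)ccc12` differs from compound 3 by 2-methoxyphenoxy in place of 3,5-dimethylbenzyl on an aromatic carbon. Among the measured compounds shown here, the steps that bear on this change run the other way: a 7.6-fold lower number from compound 1 to compound 3 (0.88 log units; beyond the scatter), and a 6.3-fold lower number from compound 2 to compound 3 (0.80 log units; beyond the scatter), both beyond the scatter. Since compound 1 carries a methoxyphenoxy group of the same kind as the entering one, a modest rise in the number is expected for compound 4, estimated as a 6.4-fold higher number from compound 3 to compound 4 (0.81 log units; beyond the scatter). Compound 4 is therefore expected to give 6000 nM in this assay, within a range of 2500 nM to 14000 nM.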

Compound 4, half-maximal effective concentration: 6400 nM
For compound 4 the middle estimate is 1.1-fold (0.03 log units) below the measured one, and the stated range covers the measured number.
By their numbers in this assay, from the lowest: compound 3; then compounds 2, 4 and 1 (each within the scatter of the next).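

In this assay, 2-methoxyphenoxy in place of 3,5-dimethylbenzyl gives a 6.8-fold higher number from compound 3 to compound 4 (0.83 log units; beyond the scatter), so the low number at this position now stands apart from three other groups. Moving the methoxy group within the phenoxy group changes little, with a 1.1-fold lower number from compound 1 to compound 4 (0.05 log units; within the scatter), and the aryl-for-aryloxy comparison gives a 1.1-fold higher number from compound 2 to compound 4 (0.03 log units; within the scatter), both within the scatter. Nothing given here explains why the 3,5-dimethylbenzyl group stands apart. Going by these compounds, whether the lower number belongs to the benzyl carbon link or to the two methyl groups stays open, as does what an amine or a carboxylic acid would give at this position.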